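The compounds below may be only part of what the source reports. "The series", "measured", "known", "first", "only" and "open" are said of these compounds alone.

Of the compounds shown here, two from this series have been tested in a functional assay on BCG823 cells (Homo sapiens) for inhibition, read by MTT assay, with a stated time of 72 h; a higher number here means a weaker inhibitor, a lower number a stronger inhibitor. Compound 1, `CN(C(=O)NC(=O)c1ccc(Cl)c(Cl)c1)c1nc(C(F)(F)F)c(C(=O)N/N=C/c2ccc([N+](=O)[O-])cc2)s1`, gives 2.13 ug/mL in this assay. Compound 2, `CN(C(=O)NC(=O)c1ccc(F)c(F)c1)c1nc(C(F)(F)F)c(C(=O)N/N=C/c2cccc(C(F)(F)F)c2)s1`, gives 4.46 ug/mL in this assay, the higher of the two numbers, and the gap to compound 1 lies beyond the usual scatter. The two compounds differ in more than one place, so the two values alone cannot be laid on a single change.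

Compound 3, `CN(C(=O)NC(=O)c1ccc(F)c(F)c1)c1nc(C(F)(F)F)c(C(=O)N/N=C/c2ccc([N+](=O)[O-])cc2)s1`, has not been measured. It differs from compound 2 in one place: 4-nitrophenyl in place of 3-(trifluoromethyl)phenyl on a carbon with a double bond to nitrogen. Compound 1 carries the same 4-nitrophenyl group, and because compound 1 gives 2.13 ug/mL, a downward step is expected from compound 2 to compound 3, estimated at a 1.6-fold lower number from compound 2 to compound 3 (0.20 log units; within the scatter). On that basis compound 3 is expected to give about 2.8 ug/mL in this assay, within a range of 1.3 ug/mL to 6 ug/mL.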

Compound 3, half-maximal inhibitory concentration: 2.99 ug/mL
Beside the measured number, compound 3's estimate is 1.1-fold (0.03 log units) below it; the range from low to high includes it.
By their numbers in this assay, from the lowest: compounds 1, 3 and 2 (each within the scatter of the next, the first and the last beyond it).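

In this assay, for the compounds shown here, the first single change at the carbon with a double bond to nitrogen, 4-nitrophenyl in place of 3-(trifluoromethyl)phenyl, gives a 1.5-fold lower number from compound 2 to compound 3 (0.17 log units; within the scatter), so this exchange of one aromatic group for another leaves no clear mark on the read-out. The compounds also now offer a single change at the carbonyl carbon, where 3,4-difluorophenyl in place of 3,4-dichlorophenyl gives a 1.4-fold higher number from compound 1 to compound 3 (0.15 log units; within the scatter), again a step too small to separate the two compounds. No measurement is available that would explain either result.

From the compounds shown here alone, it remains open whether a 4-aminophenyl or 4-carboxyphenyl group on the carbon with a double bond to nitrogen would produce a step beyond the scatter. The same question stands for a 3,4-dimethylphenyl group on the carbonyl carbon.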